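Fluoro Addition on the Primary Amide Core

The source may report more compounds than this note shows. Statements on the series, on what has been measured and on what is new or still open speak of the compounds shown alone.

Two compounds of the series have numbers in a functional assay on the whole organism with Rattus norvegicus as the target, at a dose of 20 mg/kg by the oral route; a higher number here means more inhibition at the dose given (going by the name of the read-out), a lower number less inhibition. Compound 1, `O=C(/C=C1\CCc2c1ccc(F)c2F)NC1CC1`, gives 27% in this assay. Compound 2, `NC(=O)/C=C1\CCc2cc(F)ccc21`, gives 54% in this assay, the highest of the two numbers; its nearest neighbour is compound 1, whose number lies lower by a gap beyond the scatter. For the measured compounds named here, the two compounds differ in more than one place, so no single step between them is stated; their values show only that compound 2 stands clearly higher.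

Compound 3, `NC(=O)/C=C1\CCc2c1ccc(F)c2F`, is not yet measured in this assay. It differs from compound 2 by fluoro in place of hydrogen on an aromatic carbon, the new fluoro sitting ortho to a fluoro group on the fused aromatic ring. Compound 3 shares its aromatic substitution with compound 1, which gives 27% in this assay with a different amide, while compound 2 with the primary amide gives 54%.

For this assay the step from compound 2 to compound 3 is expected to be a moderate fall, a number 14 percentage points lower from compound 2 to compound 3 (beyond the scatter), though a change within the scatter cannot be excluded. Compound 3 is estimated to give 40% in this assay, with a range from 15% to 65%.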

Compound 3, a percentage reported as inhibition, in the whole organism at one dose (the size of the read-out at that dose, not a potency): 77%
The estimate for compound 3 lay 37 percentage points below the measured number, outside the stated range (above it).
By their numbers in this assay, from the lowest: compound 1; then compound 2; then compound 3.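

In this assay, fluoro in place of hydrogen on an aromatic carbon, ortho to a fluoro group, goes with a number 23 percentage points higher from compound 2 to compound 3 (beyond the scatter), so on the primary amide this place on the ring accepts the second fluoro with a gain at the dose given, which the earlier pair, differing in more than one place, could not show. With the aromatic substitution held constant, hydrogen in place of cyclopropyl on the amide-type nitrogen goes with a number 50 percentage points higher from compound 1 to compound 3 (beyond the scatter), the larger of the two steps, so the low number of compound 1 in this assay goes with the cyclopropyl amide and not with the aromatic substitution it shares with compound 3. Nothing at hand bears on the reason for either step.

The compounds shown leave open whether the gain belongs to fluoro as such or would also appear with chloro or methoxy at the same place on the ring. They also leave open how the amide nitrogen responds to groups other than cyclopropyl, such as methyl or a longer chain, and whether either step would hold at other doses.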